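This account rests on a few compounds, and the source may have more. Where it says the series, first, only, none or still open, it means among the compounds named here.

Measured so far in a functional assay on HCT-116 cells (Homo sapiens) for antiproliferative activity, read by CCK-8 assay, with a stated time of 72 h (a lower number here means a stronger inhibitor, a higher number a weaker inhibitor), are three compounds:

- compound 1 `Nc1ccccc1NC(=O)c1ccc(COc2ccc(Cl)cc2)cc1` gives 17300 nM
- compound 2 `CCc1ccc(OCc2ccc(C(=O)Nc3ccccc3N)cc2)cc1` gives 4830 nM
- compound 3 `CC(C)c1ccc(OCc2ccc(C(=O)Nc3ccccc3N)cc2)cc1` gives 4570 nM

The numbers show a 3.8-fold lower number from compound 1 to compound 3 (0.58 log units; beyond the scatter) and also a 1.1-fold lower number from compound 2 to compound 3 (0.02 log units; within the scatter) so compound 3 stands level with compound 2 and clear of compound 1.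

The next compound is compound 4 `Nc1ccccc1NC(=O)c1ccc(COc2ccc(F)cc2)cc1` which has fluoro in place of isopropyl on an aromatic carbon, para to a large group fluoro in place of isopropyl on an aromatic carbon and has not yet been measured. Among the measured compounds shown here, no measured compound carries fluoro, so the closest guide is compound 1, which has chloro at that place. Its steps to the two alkyl compounds are both modest, namely a 3.6-fold lower number from compound 1 to compound 2 (0.55 log units; beyond the scatter) and a 3.8-fold lower number from compound 1 to compound 3 (0.58 log units; beyond the scatter) and, read backwards, they suggest that leaving the alkyl series for a halogen raises the number. The step of a 1.1-fold lower number from compound 2 to compound 3 (0.02 log units; within the scatter) bears less, since it only compares two alkyl groups. How fluoro compares with chloro is not shown by these data, so the range stays wide.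

For compound 4 the expected step is a 2.4-fold higher number from compound 3 to compound 4 (0.38 log units; beyond the scatter) in this assay with a modest rise as the likely direction. For compound 4 the estimate is 11000 nM with an expected range from 4500 nM to 26000 nM in this assay's terms.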

Compound 4, half-maximal inhibitory concentration: 3860 nM
Beside the measured number, compound 4's estimate is 2.8-fold (0.45 log units) above it; measured number below the stated range.
By their numbers in this assay, from the lowest: compounds 4, 3 and 2 (each within the scatter of the next); then compound 1.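

In this assay, fluoro on an aromatic carbon para to a large group stands level with both alkyl groups, with a 1.2-fold lower number from compound 3 to compound 4 (0.07 log units; within the scatter) and a 1.3-fold lower number from compound 2 to compound 4 (0.10 log units; within the scatter) in the printed steps, so the earlier contrast between alkyl groups and a halogen does not hold across these compounds. The two halogens instead part from each other, with a 4.5-fold lower number from compound 1 to compound 4 (0.65 log units; beyond the scatter) marking a modest step, and among these four compounds chloro alone stands clear of the other three groups at this place. No outside evidence bears on this result, so the reading stops at the numbers themselves.

The compounds shown leave open where hydrogen, bromo, methoxy or an amine at this place would fall, and so whether chloro is a lone exception or one end of a wider spread. They also leave open whether a longer chain such as n-butyl or a carboxylic acid at this place would stay level with fluoro, ethyl and isopropyl in this assay or part from them as chloro does.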